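From fluoro to methyl on a growth inhibitor

A few compounds are considered here, and "the series" means these few. Any claim that something is new, unique, unknown or untested is made for them only; others in the source may bear on it.

- compound 1 `Cc1cc(C)c2c(O)cc(-c3cccc(F)c3)nc2n1`: 64.6 nM
- compound 2 `Cc1cc(C)c2c(O)cc(-c3ccc4ccccc4c3)nc2n1`: 15800 nM
- compound 3 `Cc1cccc(-c2cc(O)c3cc(C)cnc3n2)c1`: 170 nM

In a functional assay on U-251 cells (Homo sapiens) for antiproliferative activity (a lower number here means a stronger inhibitor of growth, a higher number a weaker inhibitor of growth), compound 1 has the lowest number of the three, which makes it the strongest growth inhibitor so far. Compound 3 stands higher, beyond the usual scatter, and compound 2 stands far higher still.

The next compound, compound 4 `Cc1cccc(-c2cc(O)c3c(C)cc(C)nc3n2)c1`, keeps the core of compound 1 and changes one group: methyl in place of fluoro on an aromatic carbon. This puts methyl in place of fluoro on an aromatic carbon. Within the data shown here, no measured pair shows this change alone, so any forecast is indirect. Compound 3 has a different core but also carries a methyl in that spot, and it gives 170 nM, so a methyl there can still leave the number in the same general region. A modest rise is expected in this assay, near the edge of the scatter, and the expected step is a 1.9-fold higher number from compound 1 to compound 4 (0.27 log units; within the scatter). The estimated value for compound 4 is 120 nM, with an expected range from 40 nM to 350 nM.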

Compound 4, concentration for 50% growth inhibition: 53700 nM
Estimate against measurement, compound 4: 450-fold (2.65 log units) below; measured number outside the range, above it.
By their numbers in this assay, from the lowest: compound 1; then compound 3; then compound 2; then compound 4.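

Putting methyl in place of fluoro brings an 830-fold higher number from compound 1 to compound 4 (2.92 log units; beyond the scatter) in this assay on this core, so the spot meta to a large group is far from indifferent to the group it carries. The two groups are alike in the simple counts, each with one heavy atom, no ring and no net charge, yet compound 1 keeps strong growth inhibition and compound 4 largely loses it. Among these compounds, nothing measured here explains why so small an exchange moves the number so far.

On these data alone, whether a plain hydrogen, a chloro group, a methoxy group or an amine at this spot would stay close to compound 1 or fall towards compound 4 remains open. Also open, as far as these compounds go, is whether fluoro in this spot would give a similar gain on the core of compound 3.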